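Spiro-piperidine sigma-1 series: removing the aryl substituent

The source may hold more compounds than are shown below. What is called first, only, known or untested is meant among the compounds shown, and "the series" means these compounds.

Three compounds of a shared core, each carrying a benzyl on the piperidine nitrogen, have been measured in an assay on membranes from brain for displacement of a labelled ligand from Sigma non-opioid intracellular receptor 1 (Cavia porcellus), read by scintillation counting, with a stated time of 120 min; a higher number here means a weaker inhibitor, a lower number a stronger inhibitor. Compound 1 `COC1Cc2c(csc2-c2cccnc2)C2(CCN(Cc3ccccc3)CC2)O1` gives 2.2 nM. Compound 2 `COC1Cc2sc(-c3ccccc3)cc2C2(CCN(Cc3ccccc3)CC2)O1` gives 5.5 nM. For the measured compounds named here, compound 3 `COC1Cc2cc(-c3ccc([N+](=O)[O-])cc3)sc2C2(CCN(Cc3ccccc3)CC2)O1` gives 16 nM, the highest of the three numbers; its gap to compound 2 and its gap to compound 1 both lie beyond the scatter, so compound 3 is the weakest inhibitor of the three so far.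

Compound 4 `COC1Cc2ccsc2C2(CCN(Cc3ccccc3)CC2)O1` is the next compound in this assay. The change from compound 3 is hydrogen in place of 4-nitrophenyl on an aromatic carbon. Going by the values given here, no pair of measured compounds differs in this single place, so the step has no direct precedent within the set. The three measured compounds all carry an aryl group at a comparable position on the thiophene ring, and the unsubstituted parent has not been seen. The expectation is a modest step, of about the same size as the scatter or slightly beyond it, and most plausibly toward a higher number, since every aryl variant so far has given a value in the low range. On that basis the estimate for compound 4 is 25 nM (range 6 nM to 100 nM), an expected step of a 1.6-fold higher number from compound 3 to compound 4 (0.19 log units; within the scatter).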

Compound 4, inhibition constant: 1.9 nM
For compound 4 the middle estimate is 13-fold (1.12 log units) above the measured one; measured number outside the range, below it.
By their numbers in this assay, from the lowest: compounds 4 and 1 (each within the scatter of the next); then compound 2; then compound 3.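

Hydrogen in place of 4-nitrophenyl on this aromatic carbon, next to the ring sulfur, gives an 8.4-fold lower number from compound 3 to compound 4 (0.93 log units; beyond the scatter) in this assay. A low number at this position therefore does not depend on an aryl group, and in this one pair it is the 4-nitrophenyl compound that carries the higher number. No measured evidence on the origin of this step is at hand.

Still open, on these data alone, is whether the step reflects the whole aryl ring or only its nitro group, and how a small group such as methyl, or an amine or a carboxylic acid, would read on this same carbon. Also open, as far as these compounds go, is whether the step holds when the benzyl on the piperidine nitrogen gives way to a longer chain.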